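This account rests on a few compounds, and the source may have more. Where it says the series, first, only, none or still open, it means among the compounds named here.

Measured compounds in an assay on isolated protein for binding affinity to Apoptosis regulator Bcl-2 (Homo sapiens), read by fluorescence polarization, with stated times of 30 min and 20 min; a higher number here means a weaker inhibitor, a lower number a stronger inhibitor:
- compound 1 `COc1ccc2c(c1)c(CC(=O)NS(=O)(=O)c1ccc(NCc3ccccc3)c([N+](=O)[O-])c1)c(C)n2-c1ccc(C)cc1`: > 10000 nM, a limit of the assay rather than a number
- compound 2 `COc1ccc2c(c1)c(CC(=O)NS(=O)(=O)c1ccc(Cl)c([N+](=O)[O-])c1)c(C)n2-c1ccc(-c2ccccc2)cc1`: 720 nM
- compound 3 `COc1ccc2c(c1)c(CC(=O)NS(=O)(=O)c1ccc(NC3CCCCC3)c([N+](=O)[O-])c1)c(C)n2-c1ccc(-c2ccccc2)cc1`: > 10000 nM, likewise only a limit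

Compound 3 sits at the assay limit, so only a bound is known for it. Among the compounds with values here, compound 2 is the one measured compound with a number, and the step of an at least 13-fold higher number from compound 2 to compound 3 (1.14 log units; beyond the scatter) shows that replacing chloro with cyclohexylamino on the aromatic carbon pushed the value out to the limit; this is the only measured step, and it bears on compound 4 because the limit of > 10000 nM in this assay, at which 2 of the 3 values shown sit, shows where the readable range ends.

Compound 4 `COc1ccc2c(c1)c(CC(=O)NS(=O)(=O)c1ccc(NCc3ccccc3)c([N+](=O)[O-])c1)c(C)n2-c1ccc(-c2ccccc2)cc1` differs from compound 3 by benzyl in place of cyclohexyl on a nitrogen on an aromatic ring. The change keeps the amino attachment on the same nitrogen and swaps one six-membered carbon ring for another. Within the data shown here, compound 1 already carries benzylamino, with a different group on the indole nitrogen, and gives only a limit in this assay; compound 4 differs from compound 1 only there, and no step for that pair is measured.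

The step that the limit leaves unreadable from compound 3 to compound 4 is expected to remain within the scatter, with compound 4 most likely staying at the limit. Compound 4 is therefore estimated at 12000 nM, with a range from 3000 nM to 40000 nM.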

Compound 4, inhibition constant: > 10000 nM
Compound 4: only a limit was reported (the forecaster's own chance of this, stated with the estimate: 70%); the middle value lies beyond the limit too.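

In this assay compound 4 gives > 10000 nM, which is a limit of the assay and not a number. Benzylamino in place of chloro on an aromatic carbon now gives the same outcome as cyclohexylamino, with an at least 13-fold higher number from compound 2 to compound 4 (1.14 log units; beyond the scatter), so two different amino groups at this place, one carrying a non-aromatic ring and one an aromatic ring, both lose the readable value of the chloro compound. The steps that link compound 4 to compound 3 and to compound 1 cannot be read, so neither the swap of cyclohexyl for benzyl nor phenyl in place of methyl can be sized, and the amino compounds all rest at the end of the readable range: the limit of > 10000 nM in this assay, at which 3 of the 4 values shown sit.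

Open, on these data alone, is whether an amine such as methylamino, or a short chain ending in a carboxylic acid, on this aromatic carbon would return a readable value in this assay. Also open, as far as these compounds go, are how far past the limit compound 3 and compound 4 lie, and whether bromo or methoxy in place of chloro would shift the value of compound 2.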